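Shifting the methyl on the pyridin-2-yl arm

This account rests on a few compounds, and the source may have more. Where it says the series, first, only, none or still open, it means among the compounds named here.

In an ADME assay on the whole organism for pharmacokinetics, with Rattus norvegicus as the target, with a stated time of 6 h, at a dose of 10 mg/kg by the oral route (a lower number here means less compound in the circulation, a higher number more compound in the circulation at the dose given), compound 2 `Cc1cn2c(-c3cn[nH]c3)cnc2c(Nc2cc(Cc3ccccn3)ns2)n1` gives 6880 ng.h/mL and compound 3 `Cc1ccnc(Cc2cc(Nc3nc(C)cn4c(-c5cn[nH]c5)cnc34)sn2)c1` gives 1850 ng.h/mL; compound 1 `Cc1cn2c(-c3cn[nH]c3)cnc2c(Nc2cc(Cn3cccc3)ns2)n1` stands at "not determined" (no result reported). Compound 3 is thus the lowest of the two numbers in this assay, with compound 2 the nearest entry. For the measured compounds named here, the one measured step, a 3.7-fold lower number from compound 2 to compound 3 (0.57 log units; beyond the scatter), concerns methyl against hydrogen and does not bear directly on the change from compound 3 to compound 4. Compound 4 `Cc1ccc(Cc2cc(Nc3nc(C)cn4c(-c5cn[nH]c5)cnc34)sn2)nc1` carries 5-methylpyridin-2-yl in place of 4-methylpyridin-2-yl on a saturated chain carbon bound to an aromatic carbon. Going by the values given here, with no measured step of this kind, no change beyond the scatter is expected, and compound 4 is estimated at 1850 ng.h/mL (range 800 ng.h/mL to 4300 ng.h/mL), the expected step being no change at the digits printed from compound 3 to compound 4 (within the scatter).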

Compound 4, area under the concentration-time curve: 1370 ng.h/mL
The estimate for compound 4 lay 1.4-fold (0.13 log units) above the measured number; low and high end bracket the measured number.
By their numbers in this assay, from the lowest: compounds 4 and 3 (each within the scatter of the next); then compound 2.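

In this assay, 5-methylpyridin-2-yl in place of 4-methylpyridin-2-yl gives a 1.4-fold lower number from compound 3 to compound 4 (0.13 log units; within the scatter), so these two methyl placements are not told apart in this read-out. Set against the plain pyridin-2-yl of compound 2, the new compound shows a 5.0-fold lower number from compound 2 to compound 4 (0.70 log units; beyond the scatter) and so repeats the earlier 3.7-fold lower number from compound 2 to compound 3 (0.57 log units; beyond the scatter); both methyl placements go with a lower number. No measurement at hand accounts for this. On these data alone, whether methoxy, chlorine or an amine in place of that methyl would give a similar number stays open.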